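This account rests on a few compounds, and the source may have more. Where it says the series, first, only, none or still open, it means among the compounds named here.

Measured compounds:
compound 1 `COc1cc(O)cc(O)c1C(=O)/C=C/c1ccc(Cl)cc1`: 12200 nM in a functional assay on HepG2 cells (Homo sapiens) for inhibition, read by MTT assay, with a stated time of 72 h; on this read-out lower numbers stand for stronger inhibition and higher numbers for weaker inhibition
compound 2 `COc1cc(O)cc(O)c1C(=O)/C=C/c1ccc(C(F)(F)F)cc1`: 14100 nM in this assay
compound 3 `COc1cc(OC)c(C(=O)/C=C/c2ccc(C(F)(F)F)cc2)c(OC)c1`: 9700 nM in this assay

Compound 1 and compound 2 share one core, while compound 3 carries another; how the core of compound 3 differs from that of compound 2 is not broken down here. From compound 2 to compound 1 the change is chloro in place of trifluoromethyl on an aromatic carbon, and in this assay it gave a 1.2-fold lower number from compound 2 to compound 1 (0.06 log units; within the scatter). Compound 4, `COc1cc(OC)c(C(=O)/C=C/c2ccc(Cl)cc2)c(OC)c1`, is not yet measured; it differs from compound 3 by chloro in place of trifluoromethyl on an aromatic carbon, the same change at the same place. Since the step of a 1.2-fold lower number from compound 2 to compound 1 (0.06 log units; within the scatter) stayed within the scatter, the expected step in this assay for compound 4 is a 1.2-fold lower number from compound 3 to compound 4 (0.07 log units; within the scatter). Compound 4 is estimated at 8200 nM, with a likely range from 4000 nM to 17000 nM.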

Compound 4, half-maximal inhibitory concentration: 12400 nM
Compound 4: the middle estimate sits 1.5-fold (0.18 log units) below what was measured, within the range that was stated.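

On the core of compound 3, chloro in place of trifluoromethyl gave a 1.3-fold higher number from compound 3 to compound 4 (0.11 log units; within the scatter) in this assay. Set beside the earlier step, the two cores give no sign of treating this change differently: the same change on two cores in this assay, a 1.2-fold lower number (0.06 log units; within the scatter) from compound 2 to compound 1 and a 1.3-fold higher number (0.11 log units; within the scatter) from compound 3 to compound 4, 1.5-fold (0.17 log units) apart, within the scatter of two such steps

So the change carries from one core to the other in the sense that neither step leaves the scatter, but this does not establish a direction or any real effect of the change, and two pairs cannot speak for other cores in the series.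

The compounds shown leave open what a group such as an amine, a nitrile or a carboxylic acid would do on that same aromatic carbon. They also leave open whether any replacement there would move the number beyond the scatter on either core.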